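Exchanging the aryl group on the amide-type nitrogen

A few compounds are considered here, and "the series" means these few. Any claim that something is new, unique, unknown or untested is made for them only; others in the source may bear on it.

Measured compounds:
compound 1, `Cc1cccc(-c2noc(C3CC(=O)N(c4ccc(F)cc4)C3)n2)n1`: > 10000 nM
compound 2, `Cc1ccccc1N1CC(c2nc(-c3cccc(Cl)c3)no2)CC1=O`: > 10000 nM

Both compounds were tested in an in vitro functional assay on HEK293-A cells for positive allosteric modulation of metabotropic glutamate receptor 5 (Homo sapiens), read by FLIPR and calcium flux; on this read-out lower numbers stand for an effect already at smaller amounts and higher numbers for an effect only at larger amounts of compound. For compound 1 the result > 10000 nM is a limit of the assay, not a number. For compound 2 the result > 10000 nM is likewise a limit. Where compound 2 stands is thus known only as a limit: the limit of > 10000 nM in this assay, at which 2 of the 2 values shown sit, so the two measured values sit at the same limit and nothing separates them.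

Compound 3, `COc1cccc(N2CC(c3nc(-c4cccc(Cl)c4)no3)CC2=O)c1`, has not yet been measured. It differs from compound 2 in one place: 3-methoxyphenyl in place of 2-methylphenyl on an amide-type nitrogen in a ring. Within the data shown here, no step between two measured compounds is known, so nothing here shows how such a change moves the read-out in this assay. With both measured compounds at the limit, the step of a number no higher from compound 2 to compound 3 (the limit leaves the size open) is expected to be none beyond the scatter, most likely ending again at a limit. Compound 3 is therefore estimated at about 10000 nM, with a range from 2000 nM to 30000 nM.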

Compound 3, half-maximal effective concentration: > 10000 nM
Compound 3 was reported as a limit; the forecaster's own chance of this, stated with the estimate: 70%; the middle value sits exactly at the limit.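

No step can be read from compound 2 to compound 3, because both results, like that of compound 1, are limits and not numbers: the limit of > 10000 nM in this assay, at which 3 of the 3 values shown sit.

The compounds shown leave open whether 3-methoxyphenyl and 2-methylphenyl on the amide-type nitrogen differ at all in this assay, and which change to these structures would give a measurable value.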